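The compounds below may be only part of what the source reports. "The series", "measured", "known", "first", "only" and "open" are said of these compounds alone.

Among the compounds with values here, compound 1 `Cc1nn(C)c(Oc2ccc(Cl)cc2)c1/C=N\CCCCCOc1cc2oc(=O)cc(C)c2cc1Cl` is the first of two measured compounds; in a functional assay on U-87MG ATCC cells for antiproliferative activity against U-87 MG (Homo sapiens), read by MTT assay, with a stated time of 72 h (a lower number here means a stronger inhibitor, a higher number a weaker inhibitor), compound 1 gives 18700 nM. Compound 2 `Cc1nn(C)c(Oc2ccc(Br)cc2)c1/C=N\CCCCCOc1cc2oc(=O)cc(C)c2cc1Cl` differs from it only by bromo in place of chloro on an aromatic carbon, and in this assay compound 2 gives 15300 nM, a change described by a 1.2-fold lower number from compound 1 to compound 2 (0.09 log units; within the scatter), so the two numbers sit within the scatter of each other and neither can be ranked above the other.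

Compound 3 `Cc1ccc(Oc2c(/C=N\CCCCCOc3cc4oc(=O)cc(C)c4cc3Cl)c(C)nn2C)cc1` continues from compound 2 with the change (methyl in place of bromo on an aromatic carbon). Within the data shown here, the only measured step that bears on it is the swap from compound 1 to compound 2, a 1.2-fold lower number from compound 1 to compound 2 (0.09 log units; within the scatter), and that step stayed within the scatter; a methyl entering in place of bromo is a different exchange, so the guidance is thin. On this basis no step beyond the scatter is expected, a 1.0-fold higher number from compound 2 to compound 3 (0.02 log units; within the scatter), and compound 3 is estimated at 16000 nM, with a plausible range from 7000 nM to 36000 nM.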

Compound 3, half-maximal inhibitory concentration: 7970 nM
For compound 3 the middle estimate is 2.0-fold (0.30 log units) above the measured one, and the stated range covers the measured number.
By their numbers in this assay, from the lowest: compounds 3, 2 and 1 (each within the scatter of the next, the first and the last beyond it).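

The earlier pair only traded one halogen for another, whereas compound 3 puts a small carbon group, methyl, at the same place on the six-membered aromatic ring, para to a large group. In this assay, within the data shown here, the exchange for bromo gives a 1.9-fold lower number from compound 2 to compound 3 (0.28 log units; within the scatter) and stays unresolved, but the exchange for chloro gives a 2.3-fold lower number from compound 1 to compound 3 (0.37 log units; beyond the scatter) and is the first step at this position to pass the scatter, if only modestly. No supporting measurement accompanies these numbers, so the data offer no account of this difference.

As far as these compounds go, whether methyl is a useful choice here, or simply one point in a narrow range, remains open. A methoxy, a trifluoromethyl or an amine at this place could test that, and so could methyl moved elsewhere on the ring.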